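Swapping the octyl chain for an amide-bearing arm

The source may hold more compounds than are shown below. What is called first, only, known or untested is meant among the compounds shown, and "the series" means these compounds.

Compound 1 `CCOC(=O)C1=Cc2ccccc2OC1(OCc1cn(CC(=O)Nc2cccc(Cl)c2)nn1)C(F)(F)F` — in a functional assay on A549 cells (Homo sapiens) for inhibition, read by MTT assay, with a stated time of 24 h (a lower number here means a stronger inhibitor, a higher number a weaker inhibitor), compound 1 gives 12800 nM.
Compound 2 `CCOC(=O)C1=Cc2ccccc2OC1(OCc1cc(-c2ccc(C)cc2)no1)C(F)(F)F` — in this assay compound 2 gives > 150000 nM, which is a limit of the assay and not a number.
Compound 3 `CCCCCCCCn1cc(COC2(C(F)(F)F)Oc3ccccc3C=C2C(=O)OCC)nn1` — in this assay compound 3 gives > 150000 nM, again a limit of the assay and not a number.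

Compound 3 therefore stands at the edge of what this assay can report; of the three values shown, compound 3 shares that position with compound 2, as the limit of > 150000 nM in this assay, at which 2 of the 3 values shown sit, records. Going by the values given here, the one measured step that reaches compound 3 is an at least 11-fold higher number from compound 1 to compound 3 (1.06 log units; beyond the scatter), where heptyl took the place of (3-chlorophenyl)carbamoyl on a saturated chain carbon bound to an aromatic nitrogen and the number went up by at least that much.

Compound 4 `CCOC(=O)C1=Cc2ccccc2OC1(OCc1cn(CC(=O)Nc2ccccc2F)nn1)C(F)(F)F` differs from compound 3 by (2-fluorophenyl)carbamoyl in place of heptyl on a saturated chain carbon bound to an aromatic nitrogen. This is the reverse of the measured step in kind, with a (2-fluorophenyl)carbamoyl group entering where compound 1 carried (3-chlorophenyl)carbamoyl. Among the compounds with values here, only that step bears on the change, and it was large. Compound 4 is expected to show a correspondingly large fall in the number, an at least 10-fold lower number from compound 3 to compound 4 (1.00 log units; beyond the scatter). The estimate for compound 4 in this assay is 15000 nM, expected to lie between 5000 nM and 60000 nM.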

Compound 4, half-maximal inhibitory concentration: 50100 nM
Beside the measured number, compound 4's estimate is 3.3-fold (0.52 log units) below it; measured number inside the range.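

Compound 4 shows that the gain over the octyl chain in this assay does not depend on the 3-chlorophenyl group alone, since a second aryl amide arm at this place also gives a lower number, with an at least 2.9-fold lower number from compound 3 to compound 4 (0.47 log units; beyond the scatter). The aryl group on the amide-type nitrogen also counts, as replacing 3-chlorophenyl with 2-fluorophenyl gives a 3.9-fold higher number from compound 1 to compound 4 (0.59 log units; beyond the scatter), so the two amide-bearing arms are not interchangeable in this assay. The step from the octyl compound remains a bound and not a measured gap, since compound 3 stands at a limit of the assay and not at a number: the limit of > 150000 nM in this assay, at which 2 of the 4 values shown sit.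

The compounds shown leave open whether the gap between the two aryl amides follows from the change of halogen or from its place on the ring, as these two differences arrive together in a single step. They also leave open what a plain phenyl on the amide-type nitrogen, or a carboxylic acid or a simple methyl amide at the end of the arm, would do in this assay.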